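The compounds below may be only part of what the source reports. "The series", "measured", "known", "first", "only" and "open" are said of these compounds alone.

Series notes. Compound 1 `O=C(Cn1c(-c2ccccc2)cc(-c2ccccc2)c1-c1ccccc1)Nc1nc2ccccc2s1` and compound 2 `CCc1nnc(NC(=O)Cn2c(-c3ccccc3)cc(-c3ccccc3)c2-c2ccccc2)s1` share one core; compound 3 `O=C(Cn1c(-c2ccccc2)cc(-c2ccco2)c1-c1ccco1)Nc1nc2ccccc2s1` and compound 4 `CCc1nnc(NC(=O)Cn2c(-c3ccccc3)cc(-c3ccco3)c2-c2ccco2)s1` share another. How the core of compound 3 differs from the core of compound 1 is not broken down here.

In an ADME assay on HEK-293T cells (Homo sapiens) for cytotoxicity, read by MTT assay, with a stated time of 72 h, tested at 50 uM (a higher number here means more inhibition at the concentration tested (going by the name of the read-out), a lower number less inhibition), compound 1 gives 55%. In this assay compound 2 gives 49.3%. The change between them is 5-ethyl-1,3,4-thiadiazol-2-yl in place of 1,3-benzothiazol-2-yl on an amide-type nitrogen and it made the step of a number 5.7 percentage points lower from compound 1 to compound 2 (within the scatter). In this assay compound 3 gives 65.1%, the highest of the three measured numbers and beyond the scatter from both compound 1 and compound 2.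

The change from compound 3 to compound 4 is 5-ethyl-1,3,4-thiadiazol-2-yl in place of 1,3-benzothiazol-2-yl on an amide-type nitrogen. The surroundings of the place are word for word the same as for the earlier pair, so this is the same change carried onto a different core. Compound 4 has not yet been measured in this assay. Because a number 5.7 percentage points lower from compound 1 to compound 2 (within the scatter) stayed within the scatter, a step of similar size is expected here, a number 6.1 percentage points lower from compound 3 to compound 4 (within the scatter). This rests on a single earlier pair, and the other core need not carry the change the same way, so the range is kept wide. Compound 4 is therefore estimated at 59% in this assay, between 45% and 72%.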

Compound 4, a percentage reported as inhibition, at one concentration (the size of the read-out at that concentration, not a potency): 90.2%
Estimate against measurement, compound 4: 31.2 percentage points below; measured number above the stated range.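

On the core of compound 3, the exchange of 1,3-benzothiazol-2-yl for 5-ethyl-1,3,4-thiadiazol-2-yl on the amide-type nitrogen gives a number 25.1 percentage points higher from compound 3 to compound 4 (beyond the scatter) in this assay. The step therefore does not carry over from one core to the other with its size intact, so in this series the step on one core gives no safe reading of the step on the other: the same change on two cores in this assay, a number 5.7 percentage points lower (within the scatter) from compound 1 to compound 2 and a number 25.1 percentage points higher (beyond the scatter) from compound 3 to compound 4, 30.8 percentage points apart, beyond the scatter of two such steps

This shows that the result of the exchange depends on the core it is made on, but it rests on one pair per core and a single concentration, and it does not show which part of the difference between the cores is responsible, nor why the steps differ.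

The compounds shown leave open whether the dependence on the core is specific to 5-ethyl-1,3,4-thiadiazol-2-yl. A longer chain in place of the ethyl, or a carboxylic acid or an amine there, would be needed on both cores to test this.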